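This account rests on a few compounds, and the source may have more. Where it says the series, first, only, none or still open, it means among the compounds named here.

Compound 1, `CC(C)OC(=O)C1=CN(C(=O)c2ccc(C#N)cc2)CC(C)(C)c2cc(C#N)[nH]c21`: 116%
Compound 2, `CC(C)OC(=O)C1=CN(C(=O)c2ccc(F)c(F)c2)CC(C)(C)c2cc(C#N)[nH]c21`: 121%

In an assay on HEK293 cells for agonist activity at Bile acid receptor (Homo sapiens), read by a luciferase reporter (a lower number here means a smaller maximal response, a higher number a larger maximal response), compound 1 gives 116% and compound 2 gives 121%. Among the compounds with values here, these two numbers lie within the scatter of each other, so on what has been measured compound 2 cannot be told apart from compound 1: the only measured step, a number 5 percentage points higher from compound 1 to compound 2 (within the scatter), swaps the group on the carbonyl carbon without moving the response beyond the scatter.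

Compound 3, `CC(C)OC(=O)C1=CN(C(=O)c2cccc(Cl)c2)CC(C)(C)c2cc(C#N)[nH]c21`, has not been measured in this assay. It differs from compound 2 in one place: 3-chlorophenyl in place of 3,4-difluorophenyl on a carbonyl carbon. Within the data shown here, the one measured step that bears on this change is a number 5 percentage points higher from compound 1 to compound 2 (within the scatter), which altered the same group on the same carbonyl carbon and stayed within the scatter. On that basis no step beyond the scatter is expected from compound 2 to compound 3, and the expected change is a number 3 percentage points lower from compound 2 to compound 3 (within the scatter). Compound 3 is therefore estimated to give about 118% in this assay, with a range from 100% to 136%.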

Compound 3, largest response reached (reported as efficacy), in percent of the reference or control that the assay uses: 122%
Compound 3: middle estimate off by 4 percentage points, on the low side; the measured number falls inside the stated range.
By their numbers in this assay, from the lowest: compounds 1, 2 and 3 (each within the scatter of the next).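

In this assay, the group on the carbonyl carbon now comes in three forms, and the compounds carrying them cannot be told apart: the 3-chlorophenyl group gives a number 1 percentage points higher from compound 2 to compound 3 (within the scatter) and also a number 6 percentage points higher from compound 1 to compound 3 (within the scatter). Compound 3 thus adds a third aryl group to the two already seen, one with a single chlorine in place of two fluorines and with one heavy atom fewer than 3,4-difluorophenyl, and the maximal response stays within the scatter of both earlier compounds. Nothing at hand explains why these three groups give responses that cannot be separated.

Going by these compounds, all three groups are substituted phenyl rings, so it remains open whether the response would hold with a plain phenyl, a pyridine, a saturated cyclohexyl ring, or a group bearing an amine or a carboxylic acid. The read-out is also only the largest response reached, so these numbers leave open how much of each compound is needed to reach that response.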